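A few compounds are considered here, and "the series" means these few. Any claim that something is new, unique, unknown or untested is made for them only; others in the source may bear on it.

Measured compounds: compound 1 `CN1CCN(c2nc(-c3ccc(Cl)c(Cl)c3)nc3c2ncn3C)CC1` gives 35.3%; compound 3 `CN1CCN(c2nc(-c3cccc(Cl)c3)nc3c2ncn3C)CC1` gives 38.3%; compound 2 `Clc1ccc(Cl)c(-c2nc(N3CCCCC3)c3nc[nH]c3n2)c1` gives > 80%.

In an assay on cells for displacement of a labelled ligand from adenosine receptor A3 (Homo sapiens), read by scintillation counting and radioligand binding, with a stated time of 180 min, tested at 10 uM (on this read-out lower numbers stand for less inhibition and higher numbers for more inhibition at the one concentration tested (going by the name of the read-out)), compound 1 gives 35.3% and compound 3 gives 38.3%. The change between them, (hydrogen in place of chloro on an aromatic carbon), made a number 3 percentage points higher from compound 1 to compound 3 (within the scatter). The value of compound 2 is a limit of this assay, (the limit of > 80% in this assay, at which 1 of the 3 values shown sits). How the core of compound 2 differs from the core of compound 1 is not broken down here. Compound 4 `Clc1cccc(-c2nc(N3CCCCC3)c3nc[nH]c3n2)c1` is not yet measured in this assay; it differs from compound 2 by hydrogen in place of chloro on an aromatic carbon, the same kind of change as from compound 1 to compound 3, though the place differs: ortho to a large group and para to a chloro group here, ortho to a chloro group and para to a large group there. Since the earlier step was a number 3 percentage points higher from compound 1 to compound 3 (within the scatter), compound 4 is expected to change by about a number at least 2 percentage points lower from compound 2 to compound 4 (that floor lies within the scatter) from compound 2. Compound 4 is thus estimated at 78%, between 55% and 95%.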

Compound 4, a percentage reported as inhibition, at one concentration (the size of the read-out at that concentration, not a potency): > 80%
Compound 4: a limit, no number (the forecaster's own chance of this, stated with the estimate: 50%); at least 2 percentage points between middle value and limit.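

The step from compound 2 to compound 4 cannot be read, since both values are limits and not numbers: the limit of > 80% in this assay, at which 2 of the 4 values shown sit.

The compounds shown leave open how far hydrogen in place of chloro on an aromatic carbon shifts inhibition in compound 2.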